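The source may hold more compounds than are shown below. What is called first, only, known or untested is meant among the compounds shown, and "the series" means these compounds.

Measured compounds:
Compound 1 `Cc1cc(CCC#N)cc(C)c1Oc1cc(Nc2ccc(C#N)cc2)c(N)cc1C(F)(F)F`: in a physicochemical assay for lipophilicity, at pH 7.4 (on this read-out higher numbers stand for higher lipophilicity and lower numbers for lower lipophilicity), compound 1 gives > 5, which is a limit of the assay rather than a number.
Compound 2 `Cc1cc(/C=C/C#N)cc(C)c1Oc1cc(Nc2ccc(C#N)cc2)c(N)cc1[N+](=O)[O-]`: in this assay compound 2 gives > 5, again a limit of the assay.
Compound 3 `Cc1cc(C#N)cc(C)c1Oc1cc(Nc2ccc(C#N)cc2)c(N)cc1C(F)(F)F`: in this assay compound 3 gives > 5, also a limit of the assay.

All three values sit at the same ceiling, so compound 2 cannot be placed within the group; its reading in this assay only tells that it lies at or past the limit. This is the whole picture: the limit of > 5 in this assay, at which 3 of the 3 values shown sit.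

Compound 4 `CNC(=O)c1cc(N)c(Nc2ccc(C#N)cc2)cc1Oc1c(C)cc(/C=C/C#N)cc1C` is not yet measured. It differs from compound 2 in one place: methylcarbamoyl in place of nitro on an aromatic carbon.

Among the measured compounds shown here, no measured step concerns this change. For the measured compounds named here, the only step on record, a step that the two limits leave unreadable from compound 1 to compound 3, is itself unreadable, so no measured size guides the expectation. The structural change swaps a group with no hydrogen-bond donor for one carrying a hydrogen-bond donor, and on that basis a modest drop in this assay is expected, of about a number at least 0.40 log units lower from compound 2 to compound 4 (beyond the scatter), though it may still end at the limit.

The estimate for compound 4 in this assay is 4.6, between 3.9 and 5.3.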

Compound 4, partition coefficient: 4.12
Beside the measured number, compound 4's estimate is 0.48 log units above it, within the range that was stated.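

In this assay, among the compounds shown here, compound 4 gives 4.12, the first real number in this set rather than a limit, which shows that a change at this position can give a compound of this series a readable number. Methylcarbamoyl in place of nitro, on the aromatic carbon para to the (4-cyanophenyl)amino group, amounts to a number at least 0.88 log units lower from compound 2 to compound 4 (beyond the scatter), while the earlier step between the compounds at the limit cannot be read. This size is only a minimum, because the starting point of the step is itself a limit, and the real drop could be larger: the limit of > 5 in this assay, at which 3 of the 4 values shown sit.

The compounds shown leave open which feature of the methylcarbamoyl group matters, for instance whether a plain carboxamide, an ethylcarbamoyl group with its longer chain or a carboxylic acid at this position would give a similar number. They also leave open whether methylcarbamoyl in place of trifluoromethyl on the core of compound 3 would bring a similar drop, or whether the result holds only with the 2-cyanovinyl group that compound 2 and compound 4 share.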